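The compounds below may be only part of what the source reports. "The series", "measured", "known", "first", "only" and "open" are said of these compounds alone.

Compound 1 `COc1c(F)c(N)c2c(=O)cc(-c3ccc(N)c(F)c3)oc2c1F` and compound 2 `Nc1ccc(-c2cc(=O)c3c(N)c(F)c(Cl)c(F)c3o2)cc1F` differ only in one group on the shared core, a methoxy group in compound 1 and a chloro group in compound 2. In a functional assay on MCF7 cells (Homo sapiens) for cytotoxicity, read by neutral red uptake, with a stated time of 3 days (a lower number here means a stronger inhibitor, a higher number a weaker inhibitor), compound 1 gives 100 nM and compound 2 gives 210 nM, the step between them being a 2.1-fold higher number from compound 1 to compound 2 (0.32 log units; beyond the scatter). Compound 3 `Nc1ccc(-c2cc(=O)c3c(N)c(F)c(C(=O)O)c(F)c3o2)cc1F` carries a carboxy group at the same place. In this assay compound 3 gives only a limit, > 10000 nM, so its true number is not known. The steps into compound 3 were an at least 100-fold higher number from compound 1 to compound 3 (2.00 log units; beyond the scatter) and an at least 47-fold higher number from compound 2 to compound 3 (1.67 log units; beyond the scatter), both ending at the limit of > 10000 nM in this assay, at which 1 of the 3 values shown sits. Compound 4 `CCCCCCOCc1c(F)c(N)c2c(=O)cc(-c3ccc(N)c(F)c3)oc2c1F` has not yet been measured and differs from compound 3 as (hexyloxy)methyl in place of carboxy on an aromatic carbon. Both measured steps that brought in the carboxy group were large losses, so removing it is expected to give a large gain in this assay. The step expected from compound 3 to compound 4 is an at least 33-fold lower number from compound 3 to compound 4 (1.52 log units; beyond the scatter). Compound 4 is therefore estimated to give about 300 nM in this assay, somewhere between 80 nM and 3000 nM.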

Compound 4, half-maximal inhibitory concentration: 7100 nM
The estimate for compound 4 lay 24-fold (1.37 log units) below the measured number; the whole stated range lies below it.
By their numbers in this assay, from the lowest: compound 1; then compound 2; then compound 4. At a limit, above all of these: compound 3.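

Taking away the carboxy group does not by itself bring back a low number at this position: in this assay, (hexyloxy)methyl gives a 34-fold higher number from compound 2 to compound 4 (1.53 log units; beyond the scatter) and a 71-fold higher number from compound 1 to compound 4 (1.85 log units; beyond the scatter). Compound 3 has only a limit, so the change from it reads an at least 1.4-fold lower number from compound 3 to compound 4 (0.14 log units; that floor lies within the scatter), and no real gain over the carboxy group can be claimed: the limit of > 10000 nM in this assay, at which 1 of the 4 values shown sits A high number here therefore does not require a hydrogen-bond donor at this place, since (hexyloxy)methyl has none.

The compounds shown leave open whether the high number of compound 4 goes with the length of the chain or with its ether oxygen. A shorter methoxymethyl group and a plain hexyl chain at the same place would separate these two readings.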